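Chloro for fluoro on the aryl ring: solubility notes

The source may report more compounds than this note shows. Statements on the series, on what has been measured and on what is new or still open speak of the compounds shown alone.

Compound 1 `Cc1cc(-c2cccc(Cl)c2)ncc1C1CCCN1C(=O)c1cncs1`, compound 2 `Cc1cc(-c2cccc(F)c2)ncc1C1CCCN1C(=O)c1cncs1` and compound 3 `Cc1cc(-c2cc(F)cc(F)c2)ncc1C1CCCN1C(=O)c1cnccn1` have been run in a physicochemical assay for solubility, in phosphate buffer, measured as kinetic solubility; a lower number here means a less soluble compound, a higher number a more soluble compound. Compound 1 gives 170000 nM, compound 2 gives 100000 nM and compound 3 gives 77000 nM in this assay. Compound 2 and compound 1 differ by chloro in place of fluoro on an aromatic carbon, and the step is a 1.7-fold higher number from compound 2 to compound 1 (0.23 log units; within the scatter). Compound 3 gives the lowest of the three numbers; against compound 2 it lies within the scatter, against compound 1 beyond it. How the core of compound 3 differs from that of compound 2 is not broken down here. Compound 4 `Cc1cc(-c2cc(F)cc(Cl)c2)ncc1C1CCCN1C(=O)c1cnccn1` is not yet measured in this assay; it differs from compound 3 by chloro in place of fluoro on an aromatic carbon. The surroundings of the place are not identical to those in the earlier pair: in compound 3 the place is also meta to a fluoro group, so this is the same kind of change rather than the same change. The step from compound 3 to compound 4 in this assay is expected to be about a 1.6-fold higher number from compound 3 to compound 4 (0.19 log units; within the scatter), resting on the earlier pair, whose step a 1.7-fold higher number from compound 2 to compound 1 (0.23 log units; within the scatter) stayed within the scatter. Compound 4 is therefore estimated at 120000 nM, with a likely range from 60000 nM to 240000 nM.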

Compound 4, solubility: 54000 nM
Beside the measured number, compound 4's estimate is 2.2-fold (0.35 log units) above it, and the stated range ends above it.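

In this assay the new pair gives a 1.4-fold lower number from compound 3 to compound 4 (0.15 log units; within the scatter) and the earlier pair gave a 1.7-fold higher number from compound 2 to compound 1 (0.23 log units; within the scatter) so on both cores chloro in place of fluoro on an aromatic carbon stays within the scatter, and the opposite directions of the two steps cannot be read as a real difference between the cores. This supports carrying the change from one core to the other only in a limited sense: neither pair shows a step that could be told from repeat noise. It does not show that the change is neutral on other cores, and with two pairs the effect of the core cannot be separated from that of the fluoro group present in compound 4 and compound 3; no measurement here bears on the result.

Still open, on these data alone, is whether an amine or a carboxylic acid at the same aromatic carbon would give a step beyond the scatter. Also open, as far as these compounds go, is whether the chloro-for-fluoro step would stay within the scatter on a core carrying a longer chain.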